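Trimming a Methyl from Compound 3: What to Expect

The source may report more compounds than this note shows. Statements on the series, on what has been measured and on what is new or still open speak of the compounds shown alone.

This account concerns a small set of compounds examined in a functional assay on HL-60 cells (Homo sapiens) for antiproliferative activity, read by MTT assay; a higher number here means a weaker inhibitor, a lower number a stronger inhibitor. For the measured compounds named here, compound 1 `O[C@@H]1[C@@H](O)[C@H](Cc2ccccc2)O[C@H](COCc2ccccc2)[C@H]1OCc1ccccc1` is the only member with a number: in this assay compound 1 gives 26600 nM. Compound 2 `CCC[C@@H]1O[C@H](CO)[C@@H](O)[C@H](O)[C@H]1O` gives "not active" (no number reported) in this assay, a result reported without a number. Compound 3 `CC(C)(C)C[C@@H]1O[C@H](COCc2ccccc2)[C@@H](OCc2ccccc2)[C@H](OCc2ccccc2)[C@H]1O` likewise gives "not active" (no number reported) in this assay, again without a number. Compound 3 therefore stands nowhere on a numerical scale; it shares its outcome with compound 2, and only compound 1 provides a figure at all.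

Compound 4 `CC(C)C[C@@H]1O[C@H](COCc2ccccc2)[C@@H](OCc2ccccc2)[C@H](OCc2ccccc2)[C@H]1O` differs from compound 3 in one place: hydrogen in place of methyl on a saturated chain carbon bound to three saturated chain carbons. Said another way, tert-butyl becomes isopropyl, and neopentyl becomes isobutyl. Going by the values given here, no measured pair shows what such a change does in this assay, so the size of the step cannot be read from the data; in this assay the author expects no step beyond the usual scatter, with compound 4 remaining weak. Compound 4 is estimated at 40000 nM, within a range from 15000 nM to 100000 nM, and it may well again be reported without a number.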

Compound 4, half-maximal inhibitory concentration: 8500 nM
Estimate against measurement, compound 4: 4.7-fold (0.67 log units) above; measured number below the stated range.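

For the compounds shown here, compound 3 carries no number in this assay, so no step from it to compound 4 can be read. The compounds shown leave open how large a change tert-butyl to isopropyl makes on this core. No further data bear on this result.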